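Methyl to bromo on the shared core

This account rests on a few compounds, and the source may have more. Where it says the series, first, only, none or still open, it means among the compounds named here.

Within the data shown here, compound 1 `N#Cc1c(N)cccc1S(=O)(=O)c1ccccc1` and compound 2 `Cc1cccc(S(=O)(=O)c2cccc(N)c2C#N)c1` are the two measured members. Among the measured compounds shown here, in a functional assay on MT4 cells (Homo sapiens) for cytotoxicity (on this read-out higher numbers stand for weaker inhibition and lower numbers for stronger inhibition), compound 2 gives 179000 nM, the only true number so far. Compound 1 gives > 5000 nM in this assay, and this value is a limit of the assay, not a number.

Compound 3 `N#Cc1c(N)cccc1S(=O)(=O)c1cccc(Br)c1` carries bromo in place of methyl on an aromatic carbon, meta to a large group, relative to compound 2: bromo in place of methyl on an aromatic carbon.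

For the measured compounds named here, the only measured step that bears on this change is a step that the limit leaves unreadable from compound 1 to compound 2. It offers no size to carry over, and the limit of > 5000 nM in this assay, at which 1 of the 2 values shown sits, adds no second number. Going by the values given here, no step involves bromo. The working expectation therefore stays anchored on compound 2 at 179000 nM, with no shift beyond the usual scatter expected in this assay in either direction. The expected change is a 1.2-fold lower number from compound 2 to compound 3 (0.08 log units; within the scatter).

For compound 3 the estimated value is 150000 nM, with an expected range of 40000 nM to 400000 nM.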

Compound 3, half-maximal inhibitory concentration: > 200000 nM
Compound 3: a limit, no number (the forecaster's own chance of this, stated with the estimate: 35%); middle value at least 1.3-fold (0.12 log units) away from the limit.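

In this assay compound 3 gives no number, only a limit of the assay: the limit of > 200000 nM in this assay, at which 1 of the 3 values shown sits. Bromo in place of methyl on this aromatic carbon, meta to a large group, can therefore be read only as a floor, an at least 1.1-fold higher number from compound 2 to compound 3 (0.04 log units; that floor lies within the scatter), so the real size of the change remains unknown and nothing beyond the scatter can be claimed for it. Among these compounds, the steps from compound 1 to compound 2 and from compound 1 to compound 3 cannot be read, which leaves hydrogen at this position without any comparison, and compound 2 is still the only member of the series with a true number.

On these data alone, how far the value of compound 3 lies from that of compound 2 stays open, as does the question of whether any group on this aromatic carbon gives a number clearly apart from that of compound 2. An amine, a carboxylic acid or a longer chain such as propyl at this place would show whether the read-out responds to this position at all, provided such compounds give true numbers rather than limits.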